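The source may report more compounds than this note shows. Statements on the series, on what has been measured and on what is new or still open speak of the compounds shown alone.

Compound 1 `CC(C)N(Cc1ccccc1C(F)(F)F)C(=O)C1CCN(S(=O)(=O)c2ccc3[nH]ncc3c2)CC1` 54%
Compound 2 `O=C(C1CCN(S(=O)(=O)c2ccc3[nH]ncc3c2)CC1)N(Cc1ccccc1C(F)(F)F)C1CCC1` 84%

In a functional assay on CHO cells for positive allosteric modulation of muscarinic acetylcholine receptor M5 (Homo sapiens), read by calcium flux (a higher number here means a larger maximal response, a lower number a smaller maximal response), compound 1 gives 54%, and compound 2 gives 84%, the higher of the two values, with the step of a number 30 percentage points higher from compound 1 to compound 2 (beyond the scatter). Compound 3 `O=C(C1CCN(S(=O)(=O)c2ccc3[nH]ncc3c2)CC1)N(Cc1ccccc1C(F)(F)F)CC1CCC1` differs from compound 2 by cyclobutylmethyl in place of cyclobutyl on an amide-type nitrogen. Among the measured compounds shown here, only the step from compound 1 to compound 2 bears on it, and it concerns a different change, so no measured step shows what inserting a chain carbon does here. Compound 3 is expected to give about 78%, between 55% and 100%, meaning an expected step of a number 6 percentage points lower from compound 2 to compound 3 (within the scatter) that could fall either way.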

Compound 3, largest response reached (reported as percent of maximum), in percent of the reference or control that the assay uses: 103%
Compound 3: middle estimate off by 25 percentage points, on the low side, and the stated range ends below it.
By their numbers in this assay, from the lowest: compound 1; then compound 2; then compound 3.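

At this amide-type nitrogen, cyclobutylmethyl in place of cyclobutyl gives a number 19 percentage points higher from compound 2 to compound 3 (beyond the scatter) in this assay, so keeping the four-membered ring and adding one chain carbon still changes the maximal response. Cyclobutylmethyl in place of isopropyl gives a number 49 percentage points higher from compound 1 to compound 3 (beyond the scatter), the largest step among these compounds. Nothing available explains why this change raises the response.

As far as these compounds go, it remains open whether a longer chain, such as cyclobutylethyl, or a larger ring, such as cyclopentylmethyl, would keep this response. Whether an open n-butyl chain would match cyclobutylmethyl is also unresolved.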